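The source may report more compounds than this note shows. Statements on the series, on what has been measured and on what is new or still open speak of the compounds shown alone.

In an assay on HEK293 cells for activation of Kir3.1/Kir3.2 (Homo sapiens), read by thallium flux (on this read-out lower numbers stand for smaller maximal responses and higher numbers for larger maximal responses), compound 3, whose structure is `Cc1cc(NC(=O)Cn2nnc(-c3ccccc3)n2)n(C2CCCC2)n1`, gives 105%. This is the lowest of the two numbers at hand, and its nearest neighbour is compound 1 `Cc1cc(NC(=O)Cn2nnc(-c3ccccc3)n2)n(C2CCOCC2)n1`, which in this assay gives 115%; the gap between them, a number 10 percentage points lower from compound 1 to compound 3 (within the scatter), lies within the scatter. Compound 2 `Cc1cc(NC(=O)Cn2nnc(-c3ccccc3)n2)n(C2CCC(C)(C)CC2)n1` is reported in this assay only as a limit, > 19%, and not as a number. Because of the limit of > 19% in this assay, at which 1 of the 3 values shown sits, the steps a step that the limit leaves unreadable from compound 1 to compound 2 and a step that the limit leaves unreadable from compound 2 to compound 3 cannot be sized.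

Compound 4 `Cc1cc(NC(=O)Cn2nnc(-c3ccccc3)n2)n(CC2CCCCC2)n1` differs from compound 3 by the change (cyclohexylmethyl in place of cyclopentyl on an aromatic nitrogen). Among the compounds with values here, the one readable step among the measured pairs, a number 10 percentage points lower from compound 1 to compound 3 (within the scatter), shows that exchanging one small ring on this nitrogen for another left the maximal response within the scatter, while the limit for compound 2 leaves open whether a bulkier ring changes it. Compound 4 is therefore expected to stay close to compound 3, with a wide margin: the estimated step is a number 10 percentage points lower from compound 3 to compound 4 (within the scatter). The estimate for compound 4 in this assay is 95%, between 40% and 125%.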

Compound 4, largest response reached (Emax), in percent of the reference or control that the assay uses: 77%
Estimate against measurement, compound 4: 18 percentage points above; low and high end bracket the measured number.
By their numbers in this assay, from the lowest: compound 4; then compounds 3 and 1 (each within the scatter of the next).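

Swapping oxan-4-yl for cyclopentyl on this aromatic nitrogen had left the maximal response within the scatter, but cyclohexylmethyl gives the first readable change at this position in this assay, with a number 28 percentage points lower from compound 3 to compound 4 (beyond the scatter) and a number 38 percentage points lower from compound 1 to compound 4 (beyond the scatter). The response at this position therefore does depend on the group placed there, and the change from compound 1 is the larger of the two steps. The steps between compound 2 and compound 4 and the other steps from compound 2 cannot be read: the limit of > 19% in this assay, at which 1 of the 4 values shown sits.

From the compounds shown here alone, compound 4 changes both the ring and its link to the nitrogen, so it remains open which of these matters. A plain cyclohexyl or a cyclopentylmethyl group on this nitrogen would separate the ring from the linking carbon.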